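Iminosugar aryl ether series: cytotoxicity working notes

This account rests on a few compounds, and the source may have more. Where it says the series, first, only, none or still open, it means among the compounds named here.

Two members of the series carry a number in an ADME assay on MDBK cells (Bos taurus) for cytotoxicity, read by MTT assay; a lower number here means that less compound is tolerated, a higher number that more compound is tolerated. Compound 1 `OC[C@@H]1[C@@H](O)[C@H](O)[C@@H](O)CN1CCCc1cccc(OC2CCCCC2)c1` gives 390000 nM, while compound 2 `Cc1ccc(C(C)C)c(OCCCCCCN2C[C@H](O)[C@@H](O)[C@H](O)[C@H]2CO)c1` gives 62000 nM. Among the measured compounds shown here, compound 2 therefore stands at the lowest of the two numbers, and its only neighbour, compound 1, lies at a higher number by a margin beyond the usual scatter. For the measured compounds named here, no two measured compounds differ in a single place, so no measured step is available to calibrate the next change.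

Compound 3 `Cc1ccc(C(C)(C)C)c(OCCCCCCN2C[C@H](O)[C@@H](O)[C@H](O)[C@H]2CO)c1` differs from compound 2 by methyl in place of hydrogen on a saturated chain carbon bound to an aromatic carbon and two saturated chain carbons. A change of this size, on a saturated chain carbon bound to an aromatic carbon and two saturated chain carbons, is expected to move the number little, most likely within the scatter, with at most a slight lean toward a lower number. The step is estimated at a 1.2-fold lower number from compound 2 to compound 3 (0.09 log units; within the scatter). Compound 3 is accordingly expected near 50000 nM, within a range of 20000 nM to 150000 nM.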

Compound 3, half-maximal cytotoxic concentration: 85000 nM
Compound 3: the middle estimate sits 1.7-fold (0.23 log units) below what was measured; the measured number falls inside the stated range.
By their numbers in this assay, from the lowest: compounds 2 and 3 (each within the scatter of the next); then compound 1.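

In this assay, among the compounds shown here, the isopropyl to tert-butyl change gives the first measured step, a 1.4-fold higher number from compound 2 to compound 3 (0.14 log units; within the scatter), so compound 2 and compound 3 cannot be told apart. A methyl in place of hydrogen on a saturated chain carbon bound to an aromatic carbon and two saturated chain carbons is therefore tolerated here without a shift beyond the scatter, a reading that compound 1 and compound 2, which differ in more than one place, could not give. No measured property is at hand that bears on this result.

For the compounds shown here, only this single change at this single place can be read so far. Going by these compounds, whether a hydroxyl, an amine or a phenyl on the same carbon would also stay within the scatter of compound 2 remains open, as does the effect of a longer chain on the ring nitrogen.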